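A Second Methoxy Group and Growth Inhibition

The compounds below may be only part of what the source reports. "The series", "measured", "known", "first", "only" and "open" are said of these compounds alone.

Compound 1, `COc1ccc(C2CC(c3ccc(OCc4cn(Cc5ccc([N+](=O)[O-])cc5)nn4)cc3)=NN2C(C)=O)cc1`: 33%
Compound 2, `COc1cc(C2CC(c3ccccc3)=NN2C(C)=O)ccc1OCc1cn(Cc2ccc([N+](=O)[O-])cc2)nn1`: 11%
Compound 3, `COc1ccc(C2=NN(C(C)=O)C(c3ccc(OCc4cn(Cc5ccc([N+](=O)[O-])cc5)nn4)c(OC)c3)C2)cc1`: 84%

Three compounds were tested in a functional assay on A549 cells (Homo sapiens) for inhibition, read by sulforhodamine B assay, tested at 100 uM; a higher number here means more inhibition of growth at the concentration tested, a lower number less inhibition of growth. Compound 3 gives 84%, compound 1 gives 33% and compound 2 gives 11%. Compound 2 and compound 3 differ in one place, (methoxy in place of hydrogen on an aromatic carbon), and the step of a number 73 percentage points higher from compound 2 to compound 3 (beyond the scatter). A fourth compound, compound 4 with the structure `COc1ccc(C2CC(c3ccc(OCc4cn(Cc5ccc([N+](=O)[O-])cc5)nn4)cc3)=NN2C(C)=O)cc1OC`, has not yet been measured in this assay. It is related to compound 1 by the same kind of change, (methoxy in place of hydrogen on an aromatic carbon); the surroundings are not identical, since here the entering group stands ortho to a methoxy group and meta to a large group, whereas in compound 3 it stands para to a large group. Compound 1 and compound 2 are built on different cores, and the difference between the two cores is not broken down here. Because a number 73 percentage points higher from compound 2 to compound 3 (beyond the scatter) was large, compound 4 is expected to lie above compound 1, though with the unlike surroundings and the different core a smaller step is estimated, a number 22 percentage points higher from compound 1 to compound 4 (beyond the scatter). The estimate for compound 4 is 55%, with a range from 25% to 85%.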

Compound 4, percent growth inhibition at one concentration: 36%
Estimate against measurement, compound 4: 19 percentage points above; measured number inside the range.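

In this assay, methoxy in place of hydrogen on an aromatic carbon, read as 4-methoxyphenyl to 3,4-dimethoxyphenyl, gives a number 3 percentage points higher from compound 1 to compound 4 (within the scatter), so this step cannot tell the two compounds apart. Set beside the earlier step, the same change does not carry over from one core to the other: the same change on two cores in this assay, a number 73 percentage points higher (beyond the scatter) from compound 2 to compound 3 and a number 3 percentage points higher (within the scatter) from compound 1 to compound 4, 70 percentage points apart, beyond the scatter of two such steps This shows that the large step seen on one core cannot be assumed on another in this series, but it does not show why the steps part. The cores differ, and so do the surroundings of the entering group, which on the core of compound 1 stands ortho to a methoxy group and meta to a large group, and a single pair on each core cannot separate these.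

The compounds shown leave open how the change behaves on any further core. They also leave open whether a hydroxyl group, an amine or a longer chain such as ethoxy at the same places would follow methoxy on either core.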